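The source may report more compounds than this note shows. Statements on the series, on what has been measured and on what is new or still open speak of the compounds shown alone.

Compounds measured in an assay on isolated protein for inhibition of malate dehydrogenase, mitochondrial (Sus scrofa), with stated times of 45 min and 30 min; a lower number here means a stronger inhibitor, a higher number a weaker inhibitor:
Compound 1, `O=S(=O)(Nc1ccc(-c2nc3ccccc3o2)cc1)c1ccc(Cl)s1`, gives > 63000 nM, which is a limit of the assay and not a number.
Compound 2, `O=S(=O)(Nc1ccc(-c2nc3ccccc3o2)cc1)c1ccccc1Cl`, gives > 63000 nM, again a limit rather than a number.
Compound 3, `C=Cc1ccc(S(=O)(=O)Nc2ccc3oc(-c4ccccc4)nc3c2)cc1`, gives > 63000 nM, once more a limit and not a number.

Compound 3 therefore stands at the edge of what this assay can read, together with the other two compounds, as the limit of > 63000 nM in this assay, at which 3 of the 3 values shown sit, shows; no measured number separates any of them. Among the compounds with values here, the one measured step, a step that the two limits leave unreadable from compound 1 to compound 2, changes the ring on the sulfonyl sulfur, but both ends of it are limits, so its size cannot be read.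

Compound 4, `O=S(=O)(Nc1ccc2oc(-c3ccccc3)nc2c1)c1cccc(Cl)c1`, differs from compound 3 by 3-chlorophenyl in place of 4-vinylphenyl on a sulfonyl sulfur. This is also a swap of the ring on the sulfonyl sulfur, the same kind of place that the unreadable step touched, and no readable step gives a direction for it. With every measured value sitting at the limit, compound 4 is expected to stay in the same region, so the expected step that the limit leaves unreadable from compound 3 to compound 4 is no change beyond the scatter. Compound 4 is thus estimated at 100000 nM, within a range from 40000 nM to 300000 nM, most likely reported again only as a limit.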

Compound 4, half-maximal inhibitory concentration: > 63000 nM
Compound 4 gave a limit, no number; the forecaster's own chance of this, stated with the estimate: 85%; the middle value is on the limit's open side.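

Compound 4 gives only a limit, not a number, so the step from compound 3 to compound 4 cannot be read, because both compounds sit at the same edge of the assay: the limit of > 63000 nM in this assay, at which 4 of the 4 values shown sit.

The compounds shown leave open which structural change, if any, would give a readable number in this assay.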